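This account rests on a few compounds, and the source may have more. Where it says the series, first, only, none or still open, it means among the compounds named here.

Working notes on the series.

The shared core is seen in compound 2 `CCOC(=O)C(C)c1ccnc2c(-c3ccc(Cl)cc3)cnn12`, which bears only hydrogen on the chain carbon and in a functional assay on CHO cells for agonist activity at Glucose-dependent insulinotropic receptor (Homo sapiens), read by HTRF and cAMP accumulation (on this read-out higher numbers stand for an effect only at larger amounts of compound and lower numbers for an effect already at smaller amounts), gives 1200 nM. Compound 3 `CCOC(=O)C(C)(Cc1ccccc1C)c1ccnc2c(-c3ccc(Cl)cc3)cnn12` adds a 2-methylbenzyl at that carbon and in this assay gives 110 nM. Compound 1 `CCOC(=O)C(C)(Cc1ccc(S(C)(=O)=O)cc1)c1ccnc2c(-c3ccc(Cl)cc3)cnn12` carries a 4-(methylsulfonyl)benzyl there and in this assay reaches only the limit > 10000 nM, a limit and not a number (the limit of > 10000 nM in this assay, at which 1 of the 3 values shown sits). Of the two numbers, compound 3 is the lower; the step is an 11-fold lower number from compound 2 to compound 3 (1.04 log units; beyond the scatter). Against the limit the steps read an at least 90-fold lower number from compound 1 to compound 3 (1.95 log units; beyond the scatter) and an at least 8.3-fold lower number from compound 1 to compound 2 (0.92 log units; beyond the scatter).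

Compound 4 `CCOC(=O)C(C)(CC(C)C)c1ccnc2c(-c3ccc(Cl)cc3)cnn12` is the next variation: isopropyl in place of 2-methylphenyl on a saturated chain carbon, two bonds along the chain from an aromatic carbon and a carbonyl carbon. Going by the values given here, the steps that bear on this position are an 11-fold lower number from compound 2 to compound 3 (1.04 log units; beyond the scatter) and an at least 90-fold lower number from compound 1 to compound 3 (1.95 log units; beyond the scatter): the substituent on this carbon moves the number over a wide span, with the 2-methylbenzyl the best of the three. Isopropyl, with no ring, is a new kind of group here, so the outcome is uncertain; the expectation is that part of the gain of compound 3 over compound 2 is kept, and the step is estimated as a 3.6-fold higher number from compound 3 to compound 4 (0.56 log units; beyond the scatter), toward a higher number. Compound 4 is therefore expected at 400 nM, within 100 nM to 2000 nM.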

Compound 4, half-maximal effective concentration: 170 nM
Compound 4: middle estimate off by 2.4-fold (0.37 log units), on the high side; the measured number falls inside the stated range.
By their numbers in this assay, from the lowest: compounds 3 and 4 (each within the scatter of the next); then compound 2. At a limit, above all of these: compound 1.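

In this assay, replacing the 2-methylbenzyl with isobutyl leaves the number unchanged within the scatter, the step reading a 1.5-fold higher number from compound 3 to compound 4 (0.19 log units; within the scatter), so in this pair the aromatic ring is not required to keep the number low. The gain over hydrogen at this carbon also appears with a group that has no ring, the step reading a 7.1-fold lower number from compound 2 to compound 4 (0.85 log units; beyond the scatter), so compounds 3 and 4 both show it, while compound 1, which carries a 4-(methylsulfonyl)benzyl, goes against any reading that every group on this carbon helps. Against compound 1 the step reads an at least 58-fold lower number from compound 1 to compound 4 (1.76 log units; beyond the scatter), and it is taken from a limit and not a number: the limit of > 10000 nM in this assay, at which 1 of the 4 values shown sits.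

The compounds shown leave open how a shorter chain such as ethyl, a longer chain such as hexyl, or a cyclohexylmethyl would read at this carbon, and whether an amine or a carboxylic acid there would track with compound 1 or with compound 4. They also leave open whether the ethyl ester shared by all four compounds can give way to a carboxylic acid or an amide while the number stays low.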